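The source may report more compounds than this note shows. Statements on the series, on what has been measured and on what is new or still open speak of the compounds shown alone.

Measured so far in a toxicity assay on THP-1 cells (Homo sapiens) for inhibition; on this read-out lower numbers stand for higher toxicity in this test and higher numbers for lower toxicity in this test:
Compound 1 `Cn1c(-c2ccccc2)cnc1NC(=O)c1ccc(F)cc1`: > 100000 nM
Compound 2 `Cn1c(-c2ccccc2F)cnc1NC(=O)c1ccc(F)cc1`: > 100000 nM
Compound 3 `COc1cccc(-c2cnc(NC(=O)c3ccc(F)cc3)n2C)c1`: > 100000 nM

Compound 3 gives only a limit of the assay, > 100000 nM, and not a number. Among the compounds with values here, the other two compounds also give only limits, and the series so far shares one reading: the limit of > 100000 nM in this assay, at which 3 of the 3 values shown sit. No order can therefore be drawn among the three.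

The next compound is compound 4 `Cc1ccccc1-c1cnc(NC(=O)c2ccc(F)cc2)n1C`, which differs from compound 3 at one place: 2-methylphenyl in place of 3-methoxyphenyl on an aromatic carbon. In words, 2-methylphenyl stands in place of 3-methoxyphenyl on an aromatic carbon of a five-membered aromatic ring with 2 nitrogen.

Within the data shown here, three measured steps bear on this change: a step that the two limits leave unreadable from compound 1 to compound 2, a step that the two limits leave unreadable from compound 1 to compound 3 and a step that the two limits leave unreadable from compound 2 to compound 3. None has a readable size, and none gives a direction. Compound 2 carries 2-fluorophenyl, the measured group closest in name to 2-methylphenyl, and its limit is > 100000 nM. On that basis, no step beyond the scatter is expected in this assay, and compound 4 is expected to stay at the same limit. The estimated change is a number no higher from compound 3 to compound 4 (the limit leaves the size open). For compound 4 the estimated value is 100000 nM, with an expected range from 50000 nM to 200000 nM.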

Compound 4, half-maximal cytotoxic concentration: > 50000 nM
Compound 4: only a limit was reported; the forecaster's own chance of this, stated with the estimate: 85%; the middle value lies beyond the limit too.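

In this assay compound 4 gives only a limit, > 50000 nM. The steps to it from compound 1, compound 2 and compound 3 cannot be read, as all four values are limits. The compounds shown leave open whether any of these groups on the shared core changes the read-out in this assay, and by how much.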